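The source may report more compounds than this note shows. Statements on the series, on what has been measured and on what is new or still open speak of the compounds shown alone.

Measured compounds: compound 1 `Cn1c(=O)[nH]c2ccc(OCc3ccccc3)cc21`, "not active" (no number reported); compound 2 `CC(C)c1ccc(OCCOc2ccc3[nH]c(=O)n(C(C)C)c3c2)cc1`, 14.1%; compound 3 `CC(C)=C1C(=O)Nc2ccc(OCCOc3ccccc3)cc21`, "not active" (no number reported).

All three were tested in an assay on cells for inhibition of Amine oxidase [flavin-containing] B (Homo sapiens), read by fluorescence, with stated times of 30 min and 15 min, tested at 1 uM; a higher number here means more inhibition at the concentration tested (going by the name of the read-out), a lower number less inhibition. Compound 1 was reported as "not active" (no number reported), compound 2 gives 14.1%, and compound 3 stands without any number: it was reported as "not active" (no number reported), meaning little or no inhibition was seen, as for compound 1. From compound 3 the next compound, compound 4 `COc1ccc(OCCOc2ccc3c(c2)C(=C(C)C)C(=O)N3)cc1`, differs in a single place: methoxy in place of hydrogen on an aromatic carbon. Among the measured compounds shown here, no measured pair shows the effect of this change, so in this assay no step beyond the usual scatter is expected from compound 3 to compound 4 in either direction. Compound 4 is therefore expected to give about 5%, in the range 0% to 15%, with a fair chance that again only "not active" is reported.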

Compound 4, a percentage reported as inhibition, at one concentration (the size of the read-out at that concentration, not a potency): "not active" (no number reported)
The entry for compound 4 holds no number, so the estimate cannot be set against anything.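

Compound 3 and compound 4 are both reported only as "not active", without a number, so no step can be read between them, and no supporting evidence bears on this result. The compounds shown leave open whether going from phenyl to 4-methoxyphenyl changes inhibition at all.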